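Fluoro in place of tert-butyl in a cytotoxicity series

The source may report more compounds than this note shows. Statements on the series, on what has been measured and on what is new or still open speak of the compounds shown alone.

In an ADME assay on TERT-RPE1 cells (Homo sapiens) for cytotoxicity, read by MTT assay, with a stated time of 72 h (on this read-out higher numbers stand for weaker inhibition and lower numbers for stronger inhibition), compound 1 `COc1ccc(/C=C2/CN(C)/C(=N/c3ccc(C(C)(C)C)cc3)S2)cc1` gives 23500 nM as its result. Compound 2 `FC(F)(F)c1cc(/N=C2/NC/C(=C/c3ccccc3)S2)cc(C(F)(F)F)c1` gives 32800 nM as its result, and these two numbers lie within the usual scatter of each other, so they cannot be told apart. Compound 3 `S=C(Nc1ccccc1)N1C/C(=C/c2ccccc2)S/C1=N\c1ccccc1` gives > 100000 nM as its reading, and that reading is a limit of the assay and not a number. Among the measured compounds shown here, compound 1 therefore stands level with the only other true number available.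

Compound 4 `COc1ccc(/C=C2/CN(C)/C(=N/c3ccc(F)cc3)S2)cc1` keeps the core of compound 1 but carries fluoro in place of tert-butyl on an aromatic carbon. For the measured compounds named here, no measured pair differs in just one place, so any forecast here is loose. Compound 2 also has no tert-butyl and gives 32800 nM as its result, so only a small step toward a higher number, meaning weaker inhibition, is expected. The expected change is a 1.7-fold higher number from compound 1 to compound 4 (0.23 log units; within the scatter) in this estimate. For compound 4 the estimated value is 40000 nM with an expected range from 15000 nM to 100000 nM across repeat measurements.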

Compound 4, half-maximal inhibitory concentration: 42800 nM
Compound 4: the middle estimate sits 1.1-fold (0.03 log units) below what was measured; the measured number falls inside the stated range.
By their numbers in this assay, from the lowest: compounds 1, 2 and 4 (each within the scatter of the next). At a limit, above all of these: compound 3.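

In this assay, among the compounds shown here, this is the first pair of compounds that differ in one place only, so a single change can now be read directly. Putting fluoro in place of tert-butyl on an aromatic carbon, para to a large group, gives a 1.8-fold higher number from compound 1 to compound 4 (0.26 log units; within the scatter) and so makes no change that can be told apart from repeat-measurement noise. At this position, then, a group of 1 heavy atom and a group of 4 heavy atoms give readings that cannot be separated, though this rests on one pair and explains nothing about why.

From the compounds shown here alone, whether an amine or a carboxylic acid at this same position would move the number beyond the scatter stays open. Compound 3 gives a limit of the assay and not a number, so it cannot be placed on this scale: the limit of > 100000 nM in this assay, at which 1 of the 4 values shown sits.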